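Removing the chlorines from the dichlorophenyl analogue

The source may hold more compounds than are shown below. What is called first, only, known or untested is meant among the compounds shown, and "the series" means these compounds.

Compound 2 `Cc1cc(-c2ccc(Cl)cc2Cl)c(S(C)(=O)=O)cc1C(=O)N=C(N)N` gives 42 nM in a functional assay for inhibition of sodium/hydrogen exchanger (Oryctolagus cuniculus); a lower number here means a stronger inhibitor, a higher number a weaker inhibitor. Among the two compounds measured so far, compound 2 holds the lower number, though its distance from compound 1 `Cc1cc(-c2ccc(Cl)cc2)c(S(C)(=O)=O)cc1C(=O)N=C(N)N` lies within the scatter; compound 1 gives 45 nM in this assay. Among the compounds with values here, the single measured step, a 1.1-fold lower number from compound 1 to compound 2 (0.03 log units; within the scatter), introduced a chloro group and moved the number by an amount that stays within the scatter.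

Compound 3 `Cc1cc(-c2ccccc2)c(S(C)(=O)=O)cc1C(=O)N=C(N)N` is the unmeasured analogue, differing from compound 2 by phenyl in place of 2,4-dichlorophenyl on an aromatic carbon. The change from compound 2 to compound 3 reverses the chloro addition of the measured step and takes away the remaining chloro as well, so that step bears on it only in part. Because a 1.1-fold lower number from compound 1 to compound 2 (0.03 log units; within the scatter) lay within the scatter, the change to compound 3 is expected to be modest, with, if anything, a somewhat higher number. Compound 3 is therefore estimated at 75 nM in this assay, with a likely range from 30 nM to 190 nM. The step of a 1.8-fold higher number from compound 2 to compound 3 (0.25 log units; within the scatter) that this estimate implies is expected to lie close to the edge of the scatter.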

Compound 3, half-maximal inhibitory concentration: 19 nM
The estimate for compound 3 lay 3.9-fold (0.60 log units) above the measured number; the whole stated range lies above it.
By their numbers in this assay, from the lowest: compound 3; then compounds 2 and 1 (each within the scatter of the next).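

In this assay, within the data shown here, going from the 2,4-dichlorophenyl group to plain phenyl gives a 2.2-fold lower number from compound 2 to compound 3 (0.34 log units; beyond the scatter), and removing the single chloro of compound 1 gives a 2.4-fold lower number from compound 1 to compound 3 (0.37 log units; beyond the scatter), so both steps lie beyond the scatter, though both are modest. The earlier step, a 1.1-fold lower number from compound 1 to compound 2 (0.03 log units; within the scatter), had shown only that a second chloro made no clear difference, whereas these two steps show that the ring at this position needs no chloro at all and that the unsubstituted phenyl of compound 3 gives the lowest number of the three compounds, clearly separated from both others. No measurement is available that would explain why dropping the chloro groups lowers the number.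

The compounds shown leave open whether other groups on the phenyl ring, such as a methoxy, an amine or a carboxylic acid, would keep or lower the number of compound 3. They also leave open whether an aromatic ring is needed at this position at all, as nothing here tells how a plain methyl or a cyclohexyl group would compare with phenyl.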